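Swapping a phenylethenyl arm for a dimethoxyphenyl ring

The source may report more compounds than this note shows. Statements on the series, on what has been measured and on what is new or still open speak of the compounds shown alone.

Of the compounds shown here, three sharing one core have been measured in a functional assay on OVCAR-3 cells (Homo sapiens) for antiproliferative activity, with a stated time of 48 h; on this read-out lower numbers stand for stronger inhibition of growth and higher numbers for weaker inhibition of growth. Compound 1 `Cc1cc(O)c(C2=NN(c3ccc(S(N)(=O)=O)cc3)C(c3ccccc3O)C2)cc1Cl` gives 3730 nM, and compound 2 `Cc1cc(O)c(C2=NN(c3ccc(S(N)(=O)=O)cc3)C(c3ccccc3Cl)C2)cc1Cl` gives 3580 nM; the step of a 1.0-fold lower number from compound 1 to compound 2 (0.02 log units; within the scatter) is small. Compound 3 `Cc1cc(O)c(C2=NN(c3ccc(S(N)(=O)=O)cc3)C(/C=C/c3ccccc3)C2)cc1Cl` gives 28400 nM, the highest of the three numbers, so it is the weakest growth inhibitor here. The two steps that reach it, a 7.6-fold higher number from compound 1 to compound 3 (0.88 log units; beyond the scatter) and a 7.9-fold higher number from compound 2 to compound 3 (0.90 log units; beyond the scatter), both show that replacing an aryl ring on the saturated ring carbon with a 2-phenylethenyl chain weakens activity by a modest but clear margin.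

Compound 4 `COc1ccc(C2CC(c3cc(Cl)c(C)cc3O)=NN2c2ccc(S(N)(=O)=O)cc2)cc1OC` is not yet measured. It differs from compound 3 by 3,4-dimethoxyphenyl in place of 2-phenylethenyl on a saturated ring carbon. This is the reverse of the two measured steps: an aryl ring returns to that carbon, although it is a 3,4-dimethoxyphenyl rather than the 2-hydroxyphenyl or 2-chlorophenyl seen before, so the size of the return is uncertain. Guided by compound 1 at 3730 nM, compound 4 is expected to land near 4500 nM, between 1500 nM and 14000 nM. That estimate means a step of a 6.3-fold lower number from compound 3 to compound 4 (0.80 log units; beyond the scatter) in this assay.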

Compound 4, concentration for total growth inhibition: 9800 nM
For compound 4 the middle estimate is 2.2-fold (0.34 log units) below the measured one; the measured number falls inside the stated range.
By their numbers in this assay, from the lowest: compounds 2 and 1 (each within the scatter of the next); then compound 4; then compound 3.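

In this assay, putting an aryl ring back on this saturated ring carbon recovers only part of what the 2-phenylethenyl arm gave up, with a 2.9-fold lower number from compound 3 to compound 4 (0.46 log units; beyond the scatter). The 3,4-dimethoxyphenyl ring still falls short of the two earlier rings, with a 2.7-fold higher number from compound 2 to compound 4 (0.44 log units; beyond the scatter) and a 2.6-fold higher number from compound 1 to compound 4 (0.42 log units; beyond the scatter), so at this carbon the substituents on the ring matter as well as the presence of a ring, which the matching values of compound 1 and compound 2 could not reveal. No supporting data explain why this ring lands in the middle of the series.

The compounds shown leave open whether one methoxy group would behave like two, and how an unsubstituted phenyl ring would compare. They also leave open how a ring carrying an amine or a carboxylic acid would fare at this carbon.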